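The source may hold more compounds than are shown below. What is called first, only, known or untested is meant among the compounds shown, and "the series" means these compounds.

Working notes on the series, cytotoxicity read in a functional assay on WI-38 VA13 cells (Homo sapiens) for cytotoxicity; on this read-out higher numbers stand for an effect only at larger amounts of compound and lower numbers for an effect already at smaller amounts:

compound 1 `O=C(Nc1ccc2nc(NC(=O)C3CCCCC3)sc2c1)c1ccccc1Cl` gives 0.025 ug/mL
compound 2 `N#Cc1ccc(C(=O)Nc2ccc3nc(NC(=O)C4CCCCC4)sc3c2)cc1` gives 3.3 ug/mL
compound 3 `COCCOC(=O)Nc1nc2ccc(NC(=O)c3c(Cl)cccc3Cl)cc2s1` gives 0.011 ug/mL

Compound 3 stands lowest of the three numbers in this assay; its nearest neighbour is compound 1, whose number is higher by a margin beyond the scatter, and compound 2 lies far above both.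

Compound 4 `COc1ccccc1Nc1nc2ccc(NC(=O)c3c(Cl)cccc3Cl)cc2s1` has not been measured. It differs from compound 3 as follows:

2-methoxyphenyl in place of (2-methoxyethoxy)carbonyl on a nitrogen on an aromatic ring

Among the compounds with values here, the only measured step is a 130-fold higher number from compound 1 to compound 2 (2.12 log units; beyond the scatter), and that step concerns the group on a carbonyl carbon, not the group on the nitrogen on the aromatic ring. Within the data shown here, no measured pair in the set speaks to the exchange made here, so there is no precedent for either direction. Compound 1 and compound 3 do show that the group on this nitrogen can differ between compounds whose numbers in this assay sit within a modest margin of each other, though those two compounds also differ elsewhere.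

On that thin basis, compound 4 is expected to land near compound 3, with the step of a 1.8-fold higher number from compound 3 to compound 4 (0.26 log units; within the scatter) not expected to exceed the scatter by much in either direction. The estimate for compound 4 in this assay is 0.02 ug/mL, with a range from 0.004 ug/mL to 0.1 ug/mL.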

Compound 4, half-maximal effective concentration: > 7.2 ug/mL
Compound 4 was reported as a limit; the forecaster's own chance of this, stated with the estimate: 5%; middle value at least 360-fold (2.55 log units) from the limit.
By their numbers in this assay, from the lowest: compound 3; then compound 1; then compound 2. At a limit, above all of these: compound 4.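

Compound 4 is reported as a limit and not as a number: the limit of > 7.2 ug/mL in this assay, at which 1 of the 4 values shown sits.

In this assay, 2-methoxyphenyl in place of (2-methoxyethoxy)carbonyl on a nitrogen on an aromatic ring gives an at least 650-fold higher number from compound 3 to compound 4 (2.81 log units; beyond the scatter), so the group at this place can decide whether the read-out stays at the low end of the series or moves to its top. Within the data shown here, the only earlier step, a 130-fold higher number from compound 1 to compound 2 (2.12 log units; beyond the scatter), concerned the group on a carbonyl carbon, so the series now holds a large step at each of two places, with a single pair behind each.

The compounds shown leave open whether the step follows from the loss of the carbonyl and the oxygen-bearing chain, from the entry of the aromatic ring, or from both, as this one exchange changes all of these at once. Going by these compounds, a free amine, an acetyl group or a benzyl group on this nitrogen could separate these parts, and it also remains open whether the same exchange would give a step of like size with the 2-chlorophenyl group of compound 1 on the carbonyl carbon.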